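Moving the chlorine on the anilide ring of compound 1

This account rests on a few compounds, and the source may have more. Where it says the series, first, only, none or still open, it means among the compounds named here.

Compound 1 `CCCCNC(=O)Oc1ccc(Cl)cc1C(=O)Nc1cccc(Cl)c1` gives 4.69 in a physicochemical assay for lipophilicity (on this read-out lower numbers stand for lower lipophilicity and higher numbers for higher lipophilicity), the lowest of the three numbers measured. Compound 2 `CCCCCCCNC(=O)Oc1ccc(Cl)cc1C(=O)Nc1cccc(Cl)c1` gives 5.94 in this assay, and compound 3 `CCCCCCCCCCNC(=O)Oc1ccc(Cl)cc1C(=O)Nc1cccc(Cl)c1` gives 7.19 in this assay; the steps of a number 1.25 log units higher from compound 1 to compound 2 (beyond the scatter), a number 1.25 log units higher from compound 2 to compound 3 (beyond the scatter) and a number 2.50 log units higher from compound 1 to compound 3 (beyond the scatter) all come from lengthening the carbamate chain. Compound 4 `CCCCNC(=O)Oc1ccc(Cl)cc1C(=O)Nc1ccc(Cl)cc1` differs from compound 1 in another place: 4-chlorophenyl in place of 3-chlorophenyl on an amide-type nitrogen. Among the compounds with values here, none of the measured steps touches this anilide ring, so the chain steps do not bear on the change, and no step beyond the scatter is expected in this assay. Compound 4 is therefore estimated at 4.75, between 4.4 and 5.1, a step of a number 0.06 log units higher from compound 1 to compound 4 (within the scatter).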

Compound 4, partition coefficient: 4.69
Beside the measured number, compound 4's estimate is 0.06 log units above it; measured number inside the range.
By their numbers in this assay, from the lowest: compounds 1 and 4 (each within the scatter of the next); then compound 2; then compound 3.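

In this assay, 4-chlorophenyl in place of 3-chlorophenyl on an amide-type nitrogen gives no change at the digits printed from compound 1 to compound 4 (within the scatter) while every earlier step lay in the carbamate chain. For this pair, the position of the chlorine on the anilide ring therefore leaves the two numbers within the scatter of each other. Nothing shown here offers a reason for this result.

The compounds shown leave open whether an amine or a carboxylic acid in place of the chlorine on this ring would give a step beyond the scatter. They also leave open whether the same chlorine move would read alike with the longer chains of compound 2 and compound 3.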